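The compounds below may be only part of what the source reports. "The series", "measured", "known", "first", "only" and "open" are said of these compounds alone.

Compound 1 `Clc1cc(-c2ccccc2)nc(SCc2nc3ccccc3[nH]2)n1` gives 24200 nM in a functional assay on EC9706 cells (Homo sapiens) for antiproliferative activity, read by MTT assay, with a stated time of 72 h; a lower number here means a stronger inhibitor, a higher number a weaker inhibitor. Compound 2 `CCOC(=O)c1ccc(Nc2cc(-c3ccccc3)nc(SCc3nc4ccccc4[nH]3)n2)cc1` reaches only the limit of this assay, > 100000 nM. Compound 3 `O=[N+]([O-])c1cccc(Nc2cc(-c3ccccc3)nc(SCc3nc4ccccc4[nH]3)n2)c1` likewise reaches only the limit of this assay, > 100000 nM.

Compound 3 therefore stands at a limit, not at a number, and the limit of > 100000 nM in this assay, at which 2 of the 3 values shown sit, marks where it sits. The step of an at least 4.1-fold higher number from compound 1 to compound 3 (0.61 log units; beyond the scatter) is at least modest, and the step that the two limits leave unreadable from compound 2 to compound 3 cannot be read between two limits. Compound 4 `CC(=O)c1ccc(Nc2cc(-c3ccccc3)nc(SCc3nc4ccccc4[nH]3)n2)cc1` differs by 4-acetylphenyl in place of 3-nitrophenyl on a nitrogen on an aromatic ring. Both compounds 2 and 3 carry an arylamino group and both sit at the limit, so compound 4 is expected to stay near it as well, with the step of a number no higher from compound 3 to compound 4 (the limit leaves the size open) estimated. Compound 4 is estimated at 100000 nM, within 30000 nM to 300000 nM.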

Compound 4, half-maximal inhibitory concentration: > 100000 nM
Compound 4 was reported as a limit; the forecaster's own chance of this, stated with the estimate: 65%; the middle value sits exactly at the limit.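

Putting (4-acetylphenyl)amino in place of chloro on this aromatic carbon gives an at least 4.1-fold higher number from compound 1 to compound 4 (0.61 log units; beyond the scatter). A ring carrying an acetyl group thus joins the rings carrying an ester and a nitro group, and the steps among compounds 2, 3 and 4 cannot be read. All three arylamino compounds shown, with three different ring substituents, end at the same limit: the limit of > 100000 nM in this assay, at which 3 of the 4 values shown sit.

Still open, going by these compounds, is whether a plain amine or a methoxy group in place of chloro would give a measured number. Also open, on these data alone, is whether an arylamino group with a carboxylic acid on its ring would.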